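Urea-to-amide swap on the anilide carbonyl, third case

A few compounds are considered here, and "the series" means these few. Any claim that something is new, unique, unknown or untested is made for them only; others in the source may bear on it.

In a functional assay on OVCAR-3 cells (Homo sapiens) for inhibition, read by sulforhodamine B assay, with a stated time of 48 h (a lower number here means a stronger inhibitor of growth, a higher number a weaker inhibitor of growth), compound 1 `COc1cc(-c2nn(-c3cccc(NC(=O)Nc4cccc(C(F)(F)F)c4)c3)cc2-c2ccncc2)ccc1Cl` gives 579 nM. Compound 2 `COc1cc(-c2nn(-c3cccc(NC(=O)c4ccc(Cl)c(C(F)(F)F)c4)c3)cc2-c2ccncc2)ccc1Cl` gives 2420 nM in this assay, and compound 3 `COc1cc(-c2nn(-c3cccc(NC(=O)Nc4ccc(Cl)c(C(F)(F)F)c4)c3)cc2-c2ccncc2)ccc1Cl` gives 889 nM. Compound 3 thus holds the second highest of the three numbers: the step of a 1.5-fold higher number from compound 1 to compound 3 (0.19 log units; within the scatter) lies within the scatter, whereas a 2.7-fold lower number from compound 2 to compound 3 (0.43 log units; beyond the scatter) lies beyond it. Compound 4 `COc1cc(-c2nn(-c3cccc(NC(=O)c4ccccc4)c3)cc2-c2ccncc2)ccc1Cl` carries phenyl in place of (4-chloro-3-(trifluoromethyl)phenyl)amino on a carbonyl carbon. For the measured compounds named here, the steps that bear on this are a 2.7-fold lower number from compound 2 to compound 3 (0.43 log units; beyond the scatter), run here in reverse, and a 4.2-fold higher number from compound 1 to compound 2 (0.62 log units; beyond the scatter), both modest; a 1.5-fold higher number from compound 1 to compound 3 (0.19 log units; within the scatter) indicates that dropping the chloro contributes little, and dropping the trifluoromethyl has no measured counterpart. A modest rise is expected, a 3.4-fold higher number from compound 3 to compound 4 (0.53 log units; beyond the scatter). For compound 4 the estimate is 3000 nM, with an expected range from 1000 nM to 9000 nM.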

Compound 4, concentration for 50% growth inhibition: 334 nM
Compound 4: middle estimate off by 9.0-fold (0.95 log units), on the high side, and the stated range ends above it.
By their numbers in this assay, from the lowest: compounds 4, 1 and 3 (each within the scatter of the next, the first and the last beyond it); then compound 2.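

In this assay, the amide linkage on the carbonyl carbon does not carry a penalty of its own once that carbon bears plain phenyl: a 7.2-fold lower number from compound 2 to compound 4 (0.86 log units; beyond the scatter). Replacing the urea arm also gives a 2.7-fold lower number from compound 3 to compound 4 (0.43 log units; beyond the scatter), while a 1.7-fold lower number from compound 1 to compound 4 (0.24 log units; within the scatter), so the amino group of the urea is not required for activity at this position. No measurement shown here explains these shifts. From the compounds shown here alone, it remains open whether chloro or trifluoromethyl alone accounts for the high number of compound 2, and how a methoxy group, an amine or a carboxylic acid on that phenyl would read.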